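The compounds below may be only part of what the source reports. "The series", "measured", "known", "first", "only" and "open" are said of these compounds alone.

In an assay on isolated protein (striatum) for binding affinity to 5-hydroxytryptamine receptor 4 (Cavia porcellus), read by radioligand binding (on this read-out lower numbers stand for stronger inhibition and higher numbers for weaker inhibition), compound 2 `CCn1c(=O)n(C(=O)NCCN2CCN(C)CC2)c2ccccc21` gives 75.4 nM, the lowest of the two numbers measured, and compound 1 `CC(C)n1c(=O)n(C(=O)NCCN2CCN(C)CC2)c2ccccc21` gives 91.1 nM, close by. Compound 3 `CCCn1c(=O)n(C(=O)NCCN2CCN(C)CC2)c2ccccc21` differs from compound 2 by methyl in place of hydrogen on a saturated chain carbon, two bonds along the chain from an aromatic nitrogen; cut one bond further out, this reads as ethyl to propyl. Because the earlier chain step a 1.2-fold lower number from compound 1 to compound 2 (0.08 log units; within the scatter) stayed within the scatter, no shift beyond the scatter is expected here for compound 3 in this assay. Compound 3 is therefore estimated at 80 nM, within 40 nM to 160 nM. The expected step is a 1.1-fold higher number from compound 2 to compound 3 (0.03 log units; within the scatter).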

Compound 3, inhibition constant: 253 nM
Compound 3: middle estimate off by 3.2-fold (0.50 log units), on the low side; the measured number lies above the stated range.
By their numbers in this assay, from the lowest: compounds 2 and 1 (each within the scatter of the next); then compound 3.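

In this assay, this position on the aromatic nitrogen proves able to move the number beyond the scatter: methyl on the saturated chain carbon, two bonds along the chain from an aromatic nitrogen, gives a clear rise (a 3.4-fold higher number from compound 2 to compound 3 (0.53 log units; beyond the scatter)), and propyl in place of isopropyl gives another (a 2.8-fold higher number from compound 1 to compound 3 (0.44 log units; beyond the scatter)). Thus ethyl and isopropyl read alike, while propyl stands apart, so the step between the first two compounds gave no warning of this change. Nothing available explains the difference. From the compounds shown here alone, whether a longer chain such as butyl would raise the number further remains open. So does the effect of a hydroxyl or an amine at the end of the propyl chain.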